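This account rests on a few compounds, and the source may have more. Where it says the series, first, only, none or still open, it means among the compounds named here.

Compound 1 `c1ccc(C2=NN(C3=NC(c4ccccc4)CS3)C(c3cccc4ccccc34)C2)cc1` gives 13200 nM in a functional assay on HepG2 cells (Homo sapiens) for inhibition, read by CCK-8 assay, with a stated time of 48 h; on this read-out lower numbers stand for stronger inhibition and higher numbers for weaker inhibition.
Compound 2 `c1ccc(C2=NN(C3=NC(c4ccccc4)CS3)C(c3ccc4ccccc4c3)C2)cc1` gives 17200 nM in this assay.
Compound 3 `Cc1ccc(C2=NN(C3=NC(c4ccccc4)CS3)C(c3ccc4ccccc4c3)C2)cc1C` gives 7370 nM in this assay.

Among these three numbers compound 1 holds the second highest. Its nearest neighbour is compound 2, and that step, a 1.3-fold higher number from compound 1 to compound 2 (0.11 log units; within the scatter), lies within the scatter; the gap to compound 3 also lies within the scatter, so no order among the three can be claimed from these values alone.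

Compound 4 `Cc1ccc(C2=NN(C3=NC(c4ccccc4)CS3)C(c3cccc4ccccc34)C2)cc1` has not yet been measured. It differs from compound 1 by methyl in place of hydrogen on an aromatic carbon. Going by the values given here, the one measured step that touches the same ring is a 2.3-fold lower number from compound 2 to compound 3 (0.37 log units; beyond the scatter), a modest move. The step from compound 1 to compound 2 concerns the naphthyl group instead and lies within the scatter, so it says little here. Compound 4 carries one methyl where compound 3 carries two, so a smaller move of the same kind is expected, possibly still within the scatter. Compound 4 is therefore expected to give 8500 nM in this assay, with a range from 4500 nM to 17000 nM. The expected step is a 1.6-fold lower number from compound 1 to compound 4 (0.19 log units; within the scatter).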

Compound 4, half-maximal inhibitory concentration: 10400 nM
Beside the measured number, compound 4's estimate is 1.2-fold (0.09 log units) below it, and the stated range covers the measured number.
By their numbers in this assay, from the lowest: compounds 3, 4, 1 and 2 (each within the scatter of the next, the first and the last beyond it).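

In this assay, the change from phenyl to 4-methylphenyl on the naphthalen-1-yl compound gives a 1.3-fold lower number from compound 1 to compound 4 (0.10 log units; within the scatter) and so shows that one methyl at this place, on an aromatic carbon para to a large group, is tolerated with no readable effect. Going by these compounds alone, the only earlier change on this ring, a 2.3-fold lower number from compound 2 to compound 3 (0.37 log units; beyond the scatter) on the naphthalen-2-yl compounds, introduced 3,4-dimethylphenyl, so a single methyl on the naphthalen-1-yl compound does not by itself reproduce a step beyond the scatter. Nothing available explains either result.

The compounds shown leave open whether a single methyl would behave alike with the naphthalen-2-yl group, or 3,4-dimethylphenyl alike with the naphthalen-1-yl group. They also leave open whether a methoxy group, a chlorine atom or an amine at this place would give a step beyond the scatter.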